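The source may report more compounds than this note shows. Statements on the series, on what has been measured and on what is new or still open speak of the compounds shown alone.

Of the compounds shown here, three built on a shared core have been measured in an assay for binding affinity to Alpha-1B adrenergic receptor (Homo sapiens); a lower number here means a stronger inhibitor, a higher number a weaker inhibitor. Compound 1 `CN1CCC[C@@H]1Cn1nc(Cc2ccc(F)c(F)c2)c2ccccc2c1=O` gives 316 nM. Compound 3 `CN1CCC[C@@H]1Cn1nc(Cc2cccc(F)c2)c2ccccc2c1=O` differs from compound 1 only by hydrogen in place of fluoro on an aromatic carbon, and compound 3 gives 398 nM; this step, a 1.3-fold higher number from compound 1 to compound 3 (0.10 log units; within the scatter), lies within the scatter. Compound 2 `CN(C)CCn1nc(Cc2ccc(Cl)cc2)c2ccccc2c1=O` gives 200 nM, the lowest of the three numbers, though its gaps to compound 1 and to compound 3 both lie within the scatter, so no order among the three can be read from them. Compound 4 `CN(C)CCCn1nc(Cc2ccc(Cl)cc2)c2ccccc2c1=O` has not yet been measured. It differs from compound 2 by (dimethylamino)methyl in place of dimethylamino on a saturated chain carbon, two bonds along the chain from an aromatic nitrogen. For the measured compounds named here, no measured step touches this chain: the only step with two measured ends concerns a fluoro on an aromatic carbon, so nothing measured bears on lengthening the chain that carries the dimethylamino group. With no guidance from the data, no step beyond the scatter is expected, and the estimated step of a 1.1-fold higher number from compound 2 to compound 4 (0.04 log units; within the scatter) is accordingly small. Compound 4 is therefore expected to give about 220 nM, within a range from 80 nM to 600 nM.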

Compound 4, inhibition constant: 316 nM
Beside the measured number, compound 4's estimate is 1.4-fold (0.16 log units) below it, within the range that was stated.
By their numbers in this assay, from the lowest: compounds 2, 1, 4 and 3 (each within the scatter of the next).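

Going from the 2-(dimethylamino)ethyl chain to the 3-(dimethylamino)propyl chain gives the first measured step at this position, and in this assay it reads a 1.6-fold higher number from compound 2 to compound 4 (0.20 log units; within the scatter) with the rest of the molecule unchanged. In this one pair, the dimethylamino group can therefore sit on either chain without a difference that can be told from the scatter. No measurement shown offers an explanation for this result.

Going by these compounds, a still longer 4-(dimethylamino)butyl chain remains open, as does a morpholine or a primary amine in place of the dimethylamino group on either chain. A single pair also leaves open whether the same lengthening would give a similar step in compounds carrying a different group on the other side of the shared core.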